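Second chloro on the core: from compound 1 to compound 4

This account rests on a few compounds, and the source may have more. Where it says the series, first, only, none or still open, it means among the compounds named here.

Of the compounds shown here, three have been measured in a functional assay on KM12 cells (Homo sapiens) for cytotoxicity, read by sulforhodamine B assay, with a stated time of 48 h; a lower number here means a stronger inhibitor of growth, a higher number a weaker inhibitor of growth. Compound 1 `ClCc1cccc(Cn2cnc3ncnc(Cl)c32)c1` gives 1860 nM, which places it second highest of the three numbers. Compound 3 `ClCc1ccccc1Cn1cnc2ncnc(Cl)c21` gives 3630 nM, a value within the scatter of compound 1, so the two cannot be told apart. Compound 2 `ClCc1ccc(Cn2cnc3nc(Cl)nc(Cl)c32)cc1` gives 260 nM, a gap to compound 1 that lies beyond the scatter; compound 2 differs from compound 1 in more than one place, so its value alone cannot be assigned to any single change.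

Compound 4 `ClCc1cccc(Cn2cnc3nc(Cl)nc(Cl)c32)c1` is the next compound, and it differs from compound 1 in exactly one place: chloro in place of hydrogen on an aromatic carbon. Among the measured compounds shown here, no pair of measured compounds isolates this change. For the measured compounds named here, the only hint comes from compound 2, which also carries a chloro at that point of the core and gives 260 nM, the lowest number so far. On that basis the step is expected to go toward a lower number, of moderate size, as a 4.1-fold lower number from compound 1 to compound 4 (0.62 log units; beyond the scatter). Compound 4 is therefore estimated at 450 nM, with a plausible range from 150 nM to 1400 nM in this assay.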

Compound 4, concentration for 50% growth inhibition: 16600 nM
Compound 4: middle estimate off by 37-fold (1.57 log units), on the low side; measured number outside the range, above it.
By their numbers in this assay, from the lowest: compound 2; then compounds 1 and 3 (each within the scatter of the next); then compound 4.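

In this assay, among the compounds shown here, placing a chloro on the aromatic carbon between two ring nitrogen atoms gives an 8.9-fold higher number from compound 1 to compound 4 (0.95 log units; beyond the scatter), so on this scaffold the change moves toward weaker inhibition of growth, which no earlier pair could show. The second chloro on the core therefore does not by itself go with a low number: compound 2, which carries the same chloro on the core, gives 260 nM, whereas compound 4 gives 16600 nM, and these two differ only in where the chloromethyl group sits, so the outcome of this chloro cannot be carried over from one compound to the other. Nothing shown here gives a measured reason for the higher number of compound 4.

The compounds shown leave open whether an amine, a methyl group or a methoxy group on this same aromatic carbon would move the number in the same direction as chloro. They also leave open how large the step for this chloro would be with the chloromethyl group placed as in compound 2 or compound 3, since neither compound has a partner that differs from it only at this carbon.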